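The source may report more compounds than this note shows. Statements on the series, on what has been measured and on what is new or still open speak of the compounds shown alone.

Of the compounds shown here, three have been measured so far in a functional assay on MDA-MB-231 cells (Homo sapiens) for antiproliferative activity, read by MTT assay, with a stated time of 72 h (a lower number here means a stronger inhibitor, a higher number a weaker inhibitor), and a fourth still awaits its number. Compound 1, `CN(C)CCn1cnnc1-c1cc(Oc2ccc(NC(=O)Nc3ccc(F)c(F)c3)cc2F)ccn1`, gives a value that is a limit of the assay rather than a number: in this assay compound 1 reads > 50000 nM. Compound 2, `CN(C)CCn1cnnc1-c1cc(Oc2ccc(NC(=O)Nc3ccc(F)c(Cl)c3)cc2F)ccn1`, gives 8320 nM in this assay. Compound 3, `CN(C)CCCn1cnnc1-c1cc(Oc2ccc(NC(=O)Nc3ccc(F)c(F)c3)cc2F)ccn1`, gives 25300 nM in this assay.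

Compound 2 differs from compound 1 in a single place: chloro in place of fluoro on an aromatic carbon. That change brought an at least 6.0-fold lower number from compound 1 to compound 2 (0.77 log units; beyond the scatter); the size of this step is known only as a floor because the limit of > 50000 nM in this assay, at which 1 of the 3 values shown sits, is where compound 1 sits. Compound 3 differs from compound 1 in its core: (dimethylamino)methyl in place of dimethylamino on a saturated chain carbon, two bonds along the chain from an aromatic nitrogen. That change gave an at least 1.9-fold lower number from compound 1 to compound 3 (0.29 log units; that floor lies within the scatter).

Compound 4, `CN(C)CCCn1cnnc1-c1cc(Oc2ccc(NC(=O)Nc3ccc(F)c(Cl)c3)cc2F)ccn1`, has not yet been measured. It stands to compound 3 exactly as compound 2 stands to compound 1, with the same change in the same surroundings: chloro in place of fluoro on an aromatic carbon. The expectation for compound 4 rests on compound 2, whose step an at least 6.0-fold lower number from compound 1 to compound 2 (0.77 log units; beyond the scatter) shows what this change did on the other core, and on the starting point given by compound 3, which in this assay reads 25300 nM. For compound 4 the expected step in this assay is a 6.3-fold lower number from compound 3 to compound 4 (0.80 log units; beyond the scatter). Compound 4 is therefore estimated at 4000 nM in this assay, most likely between 1500 nM and 10000 nM.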

Compound 4, half-maximal inhibitory concentration: 14200 nM
Compound 4: middle estimate off by 3.6-fold (0.55 log units), on the low side; the whole stated range lies below it.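

On the core of compound 3, chloro in place of fluoro gave only a 1.8-fold lower number from compound 3 to compound 4 (0.25 log units; within the scatter), so this change did not carry over at the size it had on the core of compound 1: the same change on two cores in this assay, an at least 6.0-fold lower number (0.77 log units; beyond the scatter) from compound 1 to compound 2 and a 1.8-fold lower number (0.25 log units; within the scatter) from compound 3 to compound 4, at least 3.3-fold (0.52 log units) apart, beyond the scatter of two such steps. The chain change, (dimethylamino)methyl in place of dimethylamino, likewise depended on the group already present, giving a 1.7-fold higher number from compound 2 to compound 4 (0.23 log units; within the scatter) once the chloro was in place: the same change on two cores in this assay, an at least 1.9-fold lower number (0.29 log units; that floor lies within the scatter) from compound 1 to compound 3 and a 1.7-fold higher number (0.23 log units; within the scatter) from compound 2 to compound 4, at least 3.3-fold (0.52 log units) apart, beyond the scatter of two such steps. So in these four compounds, the effect of each change depended on the other and the two did not simply add up, but this is a single set of four, the earlier steps are known only as floors, and nothing here shows why the steps differ or whether the same would hold on another core, with compound 1 resting on a limit of the assay and not on a number: the limit of > 50000 nM in this assay, at which 1 of the 4 values shown sits.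

Still open, on these data alone, is whether a bromo or a methyl group in place of the chloro would behave as the chloro does here. As far as these compounds go, it is also open whether a longer chain, or a morpholine in place of the dimethylamino group, would follow the same pattern in this assay.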